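Shifting One Fluorine: Expected Solubility of Compound 3

The compounds below may be only part of what the source reports. "The series", "measured", "known", "first", "only" and "open" are said of these compounds alone.

Compound 1 `Fc1ccc(-c2nc3cnc(Nc4cc(C(F)(F)F)ccn4)cc3[nH]2)cc1F`: >= 50000 nM
Compound 2 `Fc1ccc(Nc2cc3[nH]c(-c4ccc(F)c(F)c4)nc3cn2)nc1`: >= 50000 nM

Of the compounds shown here, two have been tested in a physicochemical assay for solubility, using the shake flask method, in simulated intestinal fluid, measured as kinetic solubility, with a stated time of 20 h, at pH 6.5; a lower number here means a less soluble compound, a higher number a more soluble compound. Compound 1 reaches >= 50000 nM, which is a limit of the assay rather than a measured number. Compound 2 likewise gives >= 50000 nM, again a limit and not an exact figure. Compound 2 therefore stands at the limit of >= 50000 nM in this assay, at which 2 of the 2 values shown sit; on the numbers shown nothing separates it from compound 1, and no step between measured compounds can be read from this pair.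

Compound 3 `Fc1ccnc(Nc2cc3[nH]c(-c4ccc(F)c(F)c4)nc3cn2)c1` has not yet been measured. It differs from compound 2 by 4-fluoropyridin-2-yl in place of 5-fluoropyridin-2-yl on a nitrogen on an aromatic ring, the two having the same atoms joined differently. Within the data shown here, no measured pair shows how such a change behaves in this assay, so the expectation rests on compound 2 alone, whose value >= 50000 nM sits at the limit. The step expected in this assay is a number no higher from compound 2 to compound 3 (the limit leaves the size open), which is none beyond the scatter. Compound 3 is accordingly estimated at 50000 nM, within a range from 20000 nM to 100000 nM, most likely again reported only as a limit.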

Compound 3, solubility: >= 50000 nM
Compound 3: a limit, no number (the forecaster's own chance of this, stated with the estimate: 70%); the middle value lies on the limit itself.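

Compound 3 gives >= 50000 nM in this assay, which is a limit and not a number. No step can be read from compound 2 to compound 3 or from compound 1 to compound 3, since all three share one reading: the limit of >= 50000 nM in this assay, at which 3 of the 3 values shown sit.

The compounds shown leave open how far apart these three truly lie in this assay, and whether 4-fluoropyridin-2-yl and 5-fluoropyridin-2-yl differ there at all.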